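The source may report more compounds than this note shows. Statements on the series, on what has been measured and on what is new or still open speak of the compounds shown alone.

Measured in a functional assay on HL-60 cells (Homo sapiens) for antiproliferative activity, read by MTT assay, with a stated time of 48 h; on this read-out higher numbers stand for weaker inhibition and lower numbers for stronger inhibition:
- Compound 1 `CCn1c(N)c(-c2nc3ccccc3[nH]2)c2nc(C#N)c(C#N)nc21`: > 50000 nM (a limit)
- Compound 2 `CN1CCN(CCn2c(N)c(-c3nc4ccccc4[nH]3)c3nc(C#N)c(C#N)nc32)CC1`: 4300 nM
- Compound 3 `N#Cc1nc2c(-c3nc4ccccc4[nH]3)c(N)n(CCCO)c2nc1C#N`: > 50000 nM (a limit)

Compound 3 stands at a limit and not at a number. That limit is the limit of > 50000 nM in this assay, at which 2 of the 3 values shown sit. Compound 4 `CN(C)CCCCCn1c(N)c(-c2nc3ccccc3[nH]2)c2nc(C#N)c(C#N)nc21` differs from compound 3 at the chain end: 2-(dimethylamino)ethyl in place of hydroxy on a saturated chain carbon, three bonds along the chain from an aromatic nitrogen. Cut further out, this is 3-hydroxypropyl to 5-(dimethylamino)pentyl.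

Among the compounds with values here, two measured steps bear on it, both large. Placing 4-methylpiperazin-1-yl on the chain gave an at least 11-fold lower number from compound 1 to compound 2 (1.06 log units; beyond the scatter), and hydroxymethyl in place of that group gave an at least 11-fold higher number from compound 2 to compound 3 (1.06 log units; beyond the scatter). The step with hydroxymethyl alone, a step that the two limits leave unreadable from compound 1 to compound 3, cannot be read. Compound 4 carries a different group from compound 2, so the comparison is only approximate, and a result at the limit remains possible. Even so, a large step to a lower number is expected in this assay. The expected change is an at least 10-fold lower number from compound 3 to compound 4 (1.00 log units; beyond the scatter). Compound 4 is estimated at 5000 nM, with an expected range of 1200 nM to 30000 nM.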

Compound 4, half-maximal inhibitory concentration: 3420 nM
Compound 4: middle estimate off by 1.5-fold (0.16 log units), on the high side, within the range that was stated.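

In this assay, a 5-(dimethylamino)pentyl chain serves as well as the 4-methylpiperazin-1-yl group on its shorter chain, so the amine at the chain end need not sit in a ring, with a 1.3-fold lower number from compound 2 to compound 4 (0.10 log units; within the scatter). Compound 4 also confirms that the gain depends on an amine at this position, as the two compounds without one lie far from it, with an at least 14-fold lower number from compound 3 to compound 4 (1.16 log units; beyond the scatter) and an at least 14-fold lower number from compound 1 to compound 4 (1.16 log units; beyond the scatter). Both of these large steps start from a limit and not from a number: the limit of > 50000 nM in this assay, at which 2 of the 4 values shown sit.

Compound 4 differs from compound 2 in both chain length and end group, and the two changes cannot be told apart here. From the compounds shown here alone, it remains open what a dimethylamino group on a shorter ethyl chain would give, and whether a morpholine or a carboxylic acid at the chain end would behave like either amine.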